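This account rests on a few compounds, and the source may have more. Where it says the series, first, only, none or still open, it means among the compounds named here.

Compound 3 `COC(=O)c1cccc(NC(=O)C2CCCN(C(=O)c3cc(C(F)(F)F)cc(C(F)(F)F)c3)C2)c1` was tested in an ADME assay on PC-3 cells (Homo sapiens) for cytotoxicity, read by WST assay, tested at 100 uM (a lower number here means less inhibition, a higher number more inhibition at the concentration tested (going by the name of the read-out)), alongside two related compounds. In this assay compound 3 gives 0%, the same number as compound 1 `CC(C)(C)CC(=O)Nc1cccc(C(=O)N2CCCC(C(=O)Nc3ccc(Cl)cc3)C2)c1`, which gives 0%, while compound 2 `CC(=O)Nc1cccc(C(=O)N2CCCC(C(=O)Nc3ccc(Cl)cc3)C2)c1` gives 4%; all three values lie within the scatter of one another. Within the data shown here, the only measured step, a number 4 percentage points higher from compound 1 to compound 2 (within the scatter), concerns a different part of the molecule and is itself within the scatter. Compound 4 `O=C(Nc1cccc(-c2cnco2)c1)C1CCCN(C(=O)c2cc(C(F)(F)F)cc(C(F)(F)F)c2)C1` differs from compound 3 by 1,3-oxazol-5-yl in place of methoxycarbonyl on an aromatic carbon. Among the measured compounds shown here, no measured step touches this position, so nothing in the data points to a change, and the step of a number 2 percentage points higher from compound 3 to compound 4 (within the scatter) is expected to stay within the scatter. Compound 4 is therefore estimated at 2%, with a range from -8% to 12%.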

Compound 4, a percentage reported as inhibition, at one concentration (the size of the read-out at that concentration, not a potency): 9%
Estimate against measurement, compound 4: 7 percentage points below; the range from low to high includes it.
By their numbers in this assay, from the lowest: compounds 1, 3, 2 and 4 (each within the scatter of the next).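

Among these compounds, replacing methoxycarbonyl with 1,3-oxazol-5-yl on this aromatic carbon gives, in this assay, a number 9 percentage points higher from compound 3 to compound 4 (within the scatter), the first measured step at this position. This exchange of an open-chain ester for a five-membered aromatic ring therefore does not separate the two compounds in this read-out. The data on hand offer no explanation for the result. Still open, on these data alone, is how a carboxylic acid or an amine on this aromatic carbon would read. Also open, as far as these compounds go, is whether the same exchange would read alike on the core of compound 1.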